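Urea analogues on an aortic read-out: from nitrile to chloro

The source may report more compounds than this note shows. Statements on the series, on what has been measured and on what is new or still open speak of the compounds shown alone.

The series rests on one shared core, varied at the aryl group carried on an amide-type nitrogen and at the carbonyl or thiocarbonyl beside it. Compound 1 `CC1(C)CN(NC(=S)Nc2cccc(Cl)c2)c2cc(Cl)ccc2O1` is measured in a functional assay on thoracic aorta (Rattus norvegicus) (on this read-out higher numbers stand for an effect only at larger amounts of compound and lower numbers for an effect already at smaller amounts), and gives only a limit, > 30000 nM. Compound 2 `CC1(C)CN(NC(=O)Nc2cccc(C#N)c2)c2cc(Cl)ccc2O1` gives 1900 nM in this assay. Compound 3 `CC1(C)CN(NC(=O)Nc2ccc(C#N)cc2)c2cc(Cl)ccc2O1` gives 3700 nM in this assay; it sits at the upper of the two numbers, though the step of a 1.9-fold higher number from compound 2 to compound 3 (0.29 log units; within the scatter) is within the scatter, so compounds 2 and 3 cannot be told apart on this read-out.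

Compound 4 `CC1(C)CN(NC(=O)Nc2cccc(Cl)c2)c2cc(Cl)ccc2O1` has not yet been measured. The change from compound 3 is 3-chlorophenyl in place of 4-cyanophenyl on an amide-type nitrogen. For the measured compounds named here, no measured step covers this exact exchange; the one comparison available, a 1.9-fold higher number from compound 2 to compound 3 (0.29 log units; within the scatter), moves a nitrile between two positions on the same ring and stays within the scatter. Compound 1 shares the 3-chlorophenyl of compound 4 but differs elsewhere, and its result is a limit, as the limit of > 30000 nM in this assay, at which 1 of the 3 values shown sits, records, so it gives no number to lean on. The expected step is therefore none beyond the scatter. Compound 4 is estimated to give 2500 nM in this assay, with a range from 700 nM to 9000 nM. For compound 4 this estimate means a 1.5-fold lower number from compound 3 to compound 4 (0.17 log units; within the scatter).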

Compound 4, half-maximal effective concentration: 9900 nM
Compound 4: the middle estimate sits 4.0-fold (0.60 log units) below what was measured, outside the stated range (above it).
By their numbers in this assay, from the lowest: compounds 2 and 3 (each within the scatter of the next); then compound 4. At a limit, above all of these: compound 1.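

For the compounds shown here, the change of chloro in place of cyano on an aromatic carbon is the first single exchange whose size can be read beyond the scatter in this assay: a 5.2-fold higher number from compound 2 to compound 4 (0.72 log units; beyond the scatter). The exchange of 3-chlorophenyl for 4-cyanophenyl on an amide-type nitrogen also clears the scatter, with a 2.7-fold higher number from compound 3 to compound 4 (0.43 log units; beyond the scatter), so compound 4 stands apart from both nitrile compounds, which themselves cannot be told apart, although both steps are only modest. Nothing among the data shown accounts for this difference between the chloro and the nitrile compounds.

Compound 1 carries a thiocarbonyl where compound 4 has a carbonyl. Compound 1 gives > 30000 nM, which is a limit and not a number, so the step between these two cannot be read. On these data alone, how an amine or a carboxylic acid on the phenyl ring would stand against the chloro and the nitrile also remains open, as does any effect of such a group at this place on the read-out.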